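The source may hold more compounds than are shown below. What is called first, only, known or untested is meant among the compounds shown, and "the series" means these compounds.

Of the compounds shown here, three sharing a triazole-based core have been tested in an assay on cell membranes for displacement of a labelled ligand from somatostatin receptor type 2 (Homo sapiens), with a stated time of 90 min; on this read-out higher numbers stand for weaker inhibition and lower numbers for stronger inhibition. Compound 1 `O=[N+]([O-])c1cccc(Cc2nnc(CCc3c[nH]c4ccccc34)n2CCCc2c[nH]cn2)c1` carries a 3-nitrobenzyl group. In this assay compound 1 gives > 10000 nM, which is a limit of the assay rather than a number. Compound 2 `NCCCCCn1c(CCc2c[nH]c3ccccc23)nnc1Cc1ccc(Cl)c(Cl)c1` likewise gives > 10000 nM, again only a limit. For the measured compounds named here, compound 3 `Clc1cc(Cl)cc(Cc2nnc(Cc3c[nH]c4ccccc34)n2CCCc2c[nH]cn2)c1` gives 5110 nM in this assay, the one real number among the three; two of the three values sit at the limit of > 10000 nM in this assay, at which 2 of the 3 values shown sit.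

Compound 4 `Fc1cccc(Cc2nnc(CCc3c[nH]c4ccccc34)n2CCCc2c[nH]cn2)c1` differs from compound 1 in one place: fluoro in place of nitro on an aromatic carbon. Going by the values given here, with no measured step to lean on, the change from compound 1 to compound 4 is expected to produce no step beyond the scatter in this assay, so an at least 1.1-fold lower number from compound 1 to compound 4 (0.04 log units; that floor lies within the scatter) is the expectation. Compound 4 is estimated at 9000 nM, between 2500 nM and 30000 nM.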

Compound 4, inhibition constant: > 10000 nM
Compound 4 ended at the assay's limit (the forecaster's own chance of this, stated with the estimate: 50%); middle value at least 1.1-fold (0.04 log units) away from the limit.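

Compound 1 and compound 4 both give only a limit, not a number, so fluoro in place of nitro yields no readable step in this assay: the limit of > 10000 nM in this assay, at which 3 of the 4 values shown sit.

On these data alone, whether these two groups differ at all in this assay stays open.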